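The compounds below may be only part of what the source reports. "The series", "measured", "known", "first", "only" and "open" are said of these compounds alone.

Compound 1 `CC(C)CCn1nc(-c2cccs2)c(O)c(C2=NS(=O)(=O)c3ccccc3N2)c1=O` stands lowest of the two plain numbers in an in vitro ADME assay on microsomes from liver (Homo sapiens) for metabolic stability, tested at 5 uM (a higher number here means that the compound lasts longer, a lower number that the compound disappears faster), giving 0.2 h. Compound 3 `CC(C)CCn1nc(-c2cccs2)c(O)c(C2=NS(=O)(=O)c3cc(-c4cnoc4)ccc3N2)c1=O` gives 0.5 h in this assay, which is a 2.5-fold higher number from compound 1 to compound 3 (0.40 log units; beyond the scatter). Compound 2 `CC(C)CCn1nc(-c2cccs2)c(O)c(C2=NS(=O)(=O)c3cc(OCC(=O)NO)ccc3N2)c1=O` is reported in this assay only as a limit, > 1 h. That value sits at the limit of > 1 h in this assay, at which 1 of the 3 values shown sits. The step of an at least 5.0-fold higher number from compound 1 to compound 2 (0.69 log units; beyond the scatter) is therefore known only as a floor, and the pair of compounds 2 and 3 is an at least 2.0-fold lower number from compound 2 to compound 3 (0.30 log units; that floor lies within the scatter).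

Compound 4 `CC(=O)c1ccc2c(c1)S(=O)(=O)N=C(c1c(O)c(-c3cccs3)nn(CCC(C)C)c1=O)N2` differs from compound 1 in one place: acetyl in place of hydrogen on an aromatic carbon. Among the measured compounds shown here, the two measured steps that start from compound 1, the one to compound 2 and the one to compound 3, both raised the number, one modestly and one at least modestly. An increase of similar modest size is expected here, with the step from compound 1 to compound 4 estimated as a 2.3-fold higher number from compound 1 to compound 4 (0.35 log units; beyond the scatter). Compound 4 is accordingly expected to give about 0.45 h in this assay, within a range from 0.2 h to 1 h.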

Compound 4, half-life: 0.0717 h
Compound 4: the middle estimate sits 6.3-fold (0.80 log units) above what was measured; measured number below the stated range.
By their numbers in this assay, from the lowest: compound 4; then compound 1; then compound 3. At a limit, above all of these: compound 2.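

On this aromatic carbon, both earlier groups had raised the number, but acetyl reverses that direction in this assay: a 2.8-fold lower number from compound 1 to compound 4 (0.45 log units; beyond the scatter). Among the compounds shown, a group placed here therefore does not in itself lengthen the half-life; the direction depends on which group enters, as a 7.0-fold lower number from compound 3 to compound 4 (0.84 log units; beyond the scatter) also shows. Compound 2 stands only as a limit in this assay, > 1 h, so an at least 13-fold lower number from compound 2 to compound 4 (1.14 log units; beyond the scatter) is known only as a floor: the limit of > 1 h in this assay, at which 1 of the 4 values shown sits.

The compounds shown leave open what within acetyl goes with the shorter half-life, and whether a carboxylic acid, a primary amide or a 1-hydroxyethyl group on this carbon would fall with compound 4 or with compounds 2 and 3. They also leave open whether acetyl would lower the number on another carbon of the same ring.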